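Cytotoxicity of Bromonaphthyridine Carboxamides with a Varied Amino Side Chain

This account rests on a few compounds, and the source may have more. Where it says the series, first, only, none or still open, it means among the compounds named here.

Compound 1, `COc1cccc(CNC(=O)c2nc(Br)c3cccnc3c2N[C@H]2CC[C@H](N)CC2)c1`, in a functional assay on MCF7 cells (Homo sapiens) for cytotoxicity, read by MTT assay, with a stated time of 72 h; a higher number here means a weaker inhibitor, a lower number a stronger inhibitor: "not determined" (no result reported), no result reported.
Compound 2, `COC(=O)c1nc(Br)c2cccnc2c1N[C@H]1CC[C@H](N)CC1`, this assay: > 20000 nM, a limit.
Compound 3, `COC(=O)CNc1c(C(=O)NCc2ccc(F)cc2)nc(Br)c2cccnc12`, this assay: > 10000 nM, a limit.

The account follows compound 3. In this assay compound 3 reaches only a limit, > 10000 nM, so no single number stands for it; it is one of the entries sitting at the limit of > 10000 nM in this assay, at which 1 of the 3 values shown sits. Compound 2 likewise gives only a limit in this assay, > 20000 nM, and is the entry at the limit of > 20000 nM in this assay, at which 1 of the 3 values shown sits. For compound 1 no value is reported. Going by the values given here, with both measured values being limits, no step between measured compounds can be read, and compound 3 cannot be ranked against compound 2 at all.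

Compound 4, `NCCCCCCNc1c(C(=O)NCc2ccc(F)cc2)nc(Br)c2cccnc12`, is not yet measured. It differs from compound 3 by 5-aminopentyl in place of methoxycarbonyl on a saturated chain carbon bound to a nitrogen on an aromatic ring. With compound 3 at a limit in this assay, there is no measured step on which to rest an expectation of direction, and the change from compound 3 to compound 4 is not seen elsewhere among these compounds.

The expected step from compound 3 to compound 4 is estimated as an at least 1.2-fold lower number from compound 3 to compound 4 (0.09 log units; that floor lies within the scatter), no more than the usual scatter. Compound 4 is therefore expected to give about 8000 nM in this assay, within 1500 nM to 30000 nM, with a fair chance that only a limit is reported.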

Compound 4, half-maximal inhibitory concentration: 2000 nM
Beside the measured number, compound 4's estimate is 4.0-fold (0.60 log units) above it; the range from low to high includes it.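

Going by these compounds alone, replacing methoxycarbonyl with 5-aminopentyl on a saturated chain carbon bound to a nitrogen on an aromatic ring gives an at least 5.0-fold lower number from compound 3 to compound 4 (0.69 log units; beyond the scatter), the first step that can be read in this set, and it lies beyond the scatter. Cut one bond further out, the same change reads (methoxycarbonyl)methyl to 6-aminohexyl, and for this one pair it shows that the chain on this nitrogen can move a compound from a limit to a single number in this assay. The step is a floor and not a full size, since compound 3 stands only at a limit: the limit of > 10000 nM in this assay, at which 1 of the 4 values shown sits.

The compounds shown do not separate the amine at the end of the chain from the length of the chain, and a plain hexyl chain without the amine, or a shorter or longer aminoalkyl chain, would be needed to tell these apart. Whether a carboxylic acid in place of methoxycarbonyl would read like compound 3 or like compound 4 also stays open, and the values shown give no reason for the step.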